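Removing the cyclopropylmethoxy group from compound 1

The source may report more compounds than this note shows. Statements on the series, on what has been measured and on what is new or still open speak of the compounds shown alone.

Among the compounds with values here, only two compounds have so far been measured in an ADME assay on liver (Homo sapiens) for metabolic stability, using microsomes (a higher number here means that the compound lasts longer, a lower number that the compound disappears faster), and they sit well apart. Compound 1 (`CN1Cc2cc(ccc2S(=O)(=O)C2CC2)NC(=O)CCc2cc(ccc2OCC2CC2)[C@@H](Nc2ccc3c(N)ncc(F)c3c2)C1=O`) has the higher half-life of the pair at 0.383 h while compound 2 (`COc1ccc2cc1[C@@H](C)CN(C)C(=O)Nc1ccc(S(=O)(=O)C3CC3)c(c1)CN(C)C(=O)[C@@H]2Nc1ccc2c(N)ncc(F)c2c1`) gives 0.0667 h and so lies lower by more than the usual scatter.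

The unmeasured compound 3 (`CN1Cc2cc(ccc2S(=O)(=O)C2CC2)NC(=O)CCc2cccc(c2)[C@@H](Nc2ccc3c(N)ncc(F)c3c2)C1=O`) keeps the core of compound 1 but carries hydrogen in place of cyclopropylmethoxy on an aromatic carbon. Within the data shown here, no measured step isolates this change, since compound 1 and compound 2 differ in more than one place. The gap between them therefore cannot be read as a guide to its size or direction.

With no firm direction to go on, the change in this assay is expected to stay within the scatter. The estimated step (a 1.0-fold higher number from compound 1 to compound 3 (0.02 log units; within the scatter)) is accordingly small. Compound 3 is expected to show a half-life of 0.4 h with an estimated range of 0.15 h to 1 h as the likely span of repeat measurements.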

Compound 3, half-life: 0.217 h
Estimate against measurement, compound 3: 1.8-fold (0.27 log units) above, and the stated range covers the measured number.
By their numbers in this assay, from the lowest: compound 2; then compounds 3 and 1 (each within the scatter of the next).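

Within the data shown here, the change of cyclopropylmethoxy to hydrogen on an aromatic carbon gives the first comparison in which only one place differs, and in this assay it amounts to a 1.8-fold lower number from compound 1 to compound 3 (0.25 log units; within the scatter). The step lies within the scatter, so this assay does not separate the two compounds, and the loss of the cyclopropylmethoxy group, with its three-membered ring and its oxygen, leaves no readable mark on the half-life at this position of the shared core. Nothing measured here explains this result or says what happens to either compound in the microsomes.

This is a single pair at a single position, so it does not show whether another group on the same aromatic carbon, such as a nitrile or a carboxylic acid, would move the half-life beyond the scatter. It also leaves open whether the same exchange would give a similar step on the core of compound 2, which differs from compound 1 in more than one place and so offers no comparison for this change.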